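Two Measured Compounds and One Expected Maximal Response

The source may hold more compounds than are shown below. What is called first, only, known or untested is meant among the compounds shown, and "the series" means these compounds.

Of the compounds shown here, two built on the shared core have been measured in a functional assay on CHO cells for activation of 5-hydroxytryptamine receptor 1D (Homo sapiens), read by GTPgammaS binding; on this read-out higher numbers stand for larger maximal responses and lower numbers for smaller maximal responses. Compound 1, `c1ccc(C2CCCCN2C2CCN(CCCc3c[nH]c4ccc(-n5cnnc5)cc34)CC2)cc1`, gives 65% in this assay. Compound 2, `CN(Cc1cccs1)C1CCN(CCCc2c[nH]c3ccc(-n4cnnc4)cc23)CC1`, gives 81%. Compound 2 thus stands highest of the two numbers, and its nearest neighbour, compound 1, lies below it by a gap that goes beyond the usual scatter of such measurements. Compound 3, `CN(Cc1ccccc1)CC1CCN(CCCc2c[nH]c3ccc(-n4cnnc4)cc23)CC1`, has not yet been measured in this assay. It differs from compound 2 in one place: (benzyl(methyl)amino)methyl in place of methyl((thiophen-2-yl)methyl)amino on a saturated ring carbon. For the measured compounds named here, no step between two measured compounds matches this change, so the only guide available is that both measured compounds reach a sizeable maximal response in this assay. The expected step, a number 6 percentage points lower from compound 2 to compound 3 (within the scatter), is therefore small, a slight decrease that need not go beyond the scatter. Compound 3 is estimated to give 75% in this assay, with a range from 55% to 95%.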

Compound 3, largest response reached (reported as efficacy), in percent of the reference or control that the assay uses: 93%
Compound 3: middle estimate off by 18 percentage points, on the low side, and the stated range covers the measured number.
By their numbers in this assay, from the lowest: compound 1; then compound 2; then compound 3.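

In this assay, for the compounds shown here, putting (benzyl(methyl)amino)methyl in place of methyl((thiophen-2-yl)methyl)amino on the saturated ring carbon gives a number 12 percentage points higher from compound 2 to compound 3 (beyond the scatter) and is the first step in this set that can be read at this position. It shows that the maximal response at this position is not fixed by the thiophene-bearing group: the larger group, with its six-membered aromatic ring of carbon only and no sulfur, raises the response rather than lowering it. No measurement shown here accounts for this rise.

The step changes two things at once, the aromatic ring and the way the amine is joined to the saturated ring carbon, and the compounds shown cannot tell these two apart. Benzyl(methyl)amino placed directly on that carbon, or (methyl((thiophen-2-yl)methyl)amino)methyl, would each alter only one of the two and separate their contributions to the response.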